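Vero cytotoxicity of a thiourea cinnamoyl C-glycoside

A few compounds are considered here, and "the series" means these few. Any claim that something is new, unique, unknown or untested is made for them only; others in the source may bear on it.

Of the compounds shown here, three that share a thiourea-bearing cinnamoyl core have been tested in an ADME assay on Vero cells (Chlorocebus sabaeus) for cytotoxicity, read by resazurin assay, with a stated time of 2 days; a lower number here means that less compound is tolerated, a higher number that more compound is tolerated. Compound 1 `CC(=O)OC[C@H]1O[C@@H](CC(=O)/C=C/c2cccc(NC(=S)Nc3ccccc3)c2)[C@@H](OC(C)=O)[C@@H](OC(C)=O)[C@@H]1OC(C)=O`, the fully acetylated sugar, gives 65100 nM, and compound 2 `O=C(/C=C/c1ccc(NC(=S)Nc2ccccc2)cc1)C[C@@H]1O[C@H](CO)[C@@H](O)[C@H](O)[C@H]1O`, the free hexose analogue, gives 274000 nM. Compound 3 `CCOC(=O)/C=C/c1cccc(NC(=S)Nc2ccccc2)c1`, the ethyl ester, gives 279000 nM in this assay, which is the highest of the three numbers; its gap to compound 2 lies within the scatter, while compound 1 sits beyond the scatter below it. Compound 4 `O=C(/C=C/c1cccc(NC(=S)Nc2ccccc2)c1)C[C@@H]1OC[C@@H](O)[C@H](O)[C@H]1O` has not yet been measured. Compared with compound 3 it carries (3,4,5-trihydroxyoxan-2-yl)methyl in place of ethoxy on a carbonyl carbon. Among the compounds with values here, no step between measured compounds is known for this pairing, so the expectation rests on the free-sugar compound 2, which with 274000 nM sits close to compound 3. A change in this assay from compound 3 to compound 4 of a 1.1-fold lower number from compound 3 to compound 4 (0.05 log units; within the scatter) is expected, in effect none beyond the scatter. Compound 4 is estimated at 250000 nM, with a range from 110000 nM to 550000 nM.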

Compound 4, half-maximal cytotoxic concentration: 289000 nM
For compound 4 the middle estimate is 1.2-fold (0.06 log units) below the measured one; the measured number falls inside the stated range.
By their numbers in this assay, from the lowest: compound 1; then compounds 2, 3 and 4 (each within the scatter of the next).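

In this assay the exchange of ethoxy for (3,4,5-trihydroxyoxan-2-yl)methyl on a carbonyl carbon gives a 1.0-fold higher number from compound 3 to compound 4 (0.02 log units; within the scatter), which stays within the scatter. This is the only pair shown that differs in one place, and it shows that this place on the shared core accepts a much larger group, one that brings a six-membered non-aromatic ring, hydrogen-bond donors and defined stereocentres, with no change beyond the scatter. No measured evidence accounts for this result.

Going by these compounds, it remains open whether other groups on this carbonyl carbon, such as an amine or a longer alkyl chain, would behave alike. Also open, on these data alone, is whether acetyl groups on the sugar of compound 4 would shift its number in this assay.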